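Swapping an aldehyde for chlorine on a diaminoquinazoline core

This account rests on a few compounds, and the source may have more. Where it says the series, first, only, none or still open, it means among the compounds named here.

Measured compounds:
compound 1, `Nc1nc(N)c2c(Sc3ccc(Cl)c(Cl)c3)cccc2n1`, 200 nM
compound 2, `Nc1nc(N)c2cc(C=O)ccc2n1`, 10000 nM
compound 3, `Nc1nc(N)c2c(Cl)c(N)ccc2n1`, 661 nM

Of the compounds shown here, three sharing one core have been tested in an assay for inhibition of Dihydrofolate reductase (Rattus norvegicus); on this read-out lower numbers stand for stronger inhibition and higher numbers for weaker inhibition. Among them compound 2 stands at the top of the numbers, meaning it is the weakest inhibitor of the three: its gap to compound 3 and its gap to compound 1 both lie beyond the usual scatter of this assay.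

The next compound to be measured is compound 4, `Nc1nc(N)c2cc(Cl)ccc2n1`. It differs from compound 2 in one place: chloro in place of formyl on an aromatic carbon. Within the data shown here, no pair of measured compounds differs in exactly this way, so there is no directly comparable step to lean on. Still, compound 3, which also carries a chloro group on the core, gives 661 nM, a far lower number than compound 2. On that basis the step is expected to move downward, toward stronger inhibition, by more than the scatter: a 6.7-fold lower number from compound 2 to compound 4 (0.82 log units; beyond the scatter). Compound 4 is therefore estimated at 1500 nM in this assay, with a plausible range from 300 nM to 6000 nM.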

Compound 4, half-maximal inhibitory concentration: 3980 nM
Compound 4: the middle estimate sits 2.7-fold (0.42 log units) below what was measured, and the stated range covers the measured number.
By their numbers in this assay, from the lowest: compound 1; then compound 3; then compound 4; then compound 2.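

In this assay, among these compounds, chloro in place of formyl on this aromatic carbon gives the first direct reading of a change at this position: a 2.5-fold lower number from compound 2 to compound 4 (0.40 log units; beyond the scatter) is a modest step, though it lies beyond the usual scatter. The position therefore accepts a group with one heavy atom and no hydrogen-bond acceptor in place of one with two heavy atoms and one acceptor, and inhibition becomes somewhat stronger rather than being lost. Nothing measured here explains why the swap has this effect.

From the compounds shown here alone, only these two groups can be compared on this carbon, so it remains open how an amine, a carboxylic acid or a longer chain would fare there. Compound 1 and compound 3 each differ from compound 4 in more than one place, so they cannot show how much this position alone contributes.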